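Swapping a hydroxyalkyl tail for a phenylpropyl chain

A few compounds are considered here, and "the series" means these few. Any claim that something is new, unique, unknown or untested is made for them only; others in the source may bear on it.

Measured so far:
- compound 1, `COc1ccc(CNc2nc([SeH])nc3ccccc23)cc1`, 7110 nM
- compound 2, `CSc1nc(NCCCCCO)c2ccccc2n1`, 31400 nM
- compound 3, `C[Se]c1nc([Se]C)c2cccnc2n1`, "not determined" (no result reported)

The measurements come from a functional assay on HTB-54 cells (Homo sapiens) for cytotoxicity, read by MTT assay, with a stated time of 72 h; a lower number here means a stronger inhibitor of growth, a higher number a weaker inhibitor of growth. Among the two compounds with a number, compound 2 gives 31400 nM, the higher of the two, while compound 1 gives 7110 nM, a gap that lies beyond the usual scatter. Compound 3 was tested but has no reported number, so it gives no guidance.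

The unmeasured compound 4, `CSc1nc(NCCCc2ccccc2)c2ccccc2n1`, shares the core of compound 2 and differs from it in one place: phenyl in place of 2-hydroxyethyl on a saturated chain carbon, three bonds along the chain from a nitrogen on an aromatic ring. Among the compounds with values here, no pair of measured compounds shows this exact change, so the size of its effect is unknown from the data. Compound 1 carries an aromatic ring on its chain, and its lower number offers a faint hint that such a ring can sit with a lower value, though compound 1 also differs from compound 2 elsewhere and the hint is weak. The step from compound 2 to compound 4 is expected to be modest, toward a lower number, a 2.1-fold lower number from compound 2 to compound 4 (0.32 log units; beyond the scatter), and may not exceed the scatter. Compound 4 is expected to give about 15000 nM, within a range from 5000 nM to 45000 nM.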

Compound 4, concentration for 50% growth inhibition: 50600 nM
Compound 4: middle estimate off by 3.4-fold (0.53 log units), on the low side; the whole stated range lies below it.
By their numbers in this assay, from the lowest: compound 1; then compounds 2 and 4 (each within the scatter of the next).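

In this assay, placing phenyl where 2-hydroxyethyl stood, on this saturated chain carbon, gives a 1.6-fold higher number from compound 2 to compound 4 (0.21 log units; within the scatter) and so leaves the two compounds indistinguishable. At this position, then, a tail with one hydrogen-bond donor and one acceptor and a tail with neither, carrying a six-membered aromatic ring instead, read alike in this cell test. No measurement at hand offers a reason for this result.

Going by these compounds, it remains open whether an amine or a carboxylic acid in place of the phenyl would shift the number beyond the usual scatter. On these data alone, it is equally open whether a longer chain carrying the phenyl, or a phenyl bearing a methoxy group, would do so.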